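Notes on the aryl change from compound 1 to compound 3

This account rests on a few compounds, and the source may have more. Where it says the series, first, only, none or still open, it means among the compounds named here.

Compound 1 `O=C(CCc1cccc2c1B(O)OC2)Nc1cccc(-c2cccc(F)c2)c1` is tested in a functional assay on SK-OV-3 cells (Homo sapiens) for antiproliferative activity, read by MTT assay, with a stated time of 72 h (a lower number here means a stronger inhibitor, a higher number a weaker inhibitor), where compound 1 gives 480 nM. Of the two numbers recorded so far, that of compound 1 is the highest, but the only other one lies within the scatter of it: compound 2 `O=C(CCc1cccc2c1B(O)OC2)Nc1cccc(-c2cccc(OC(F)(F)F)c2)c1` gives 460 nM in this assay, and the step of a 1.0-fold lower number from compound 1 to compound 2 (0.02 log units; within the scatter) stays inside the usual spread of repeat measurements. Compound 3 `CSc1ccc(-c2cccc(NC(=O)CCc3cccc4c3B(O)OC4)c2)cc1` has not yet been measured. It differs from compound 1 by 4-(methylsulfanyl)phenyl in place of 3-fluorophenyl on an aromatic carbon. Among the compounds with values here, the one measured step, a 1.0-fold lower number from compound 1 to compound 2 (0.02 log units; within the scatter), concerns a substituent change on the 3-fluorophenyl group of compound 1 and shows no movement beyond the scatter. That step does not involve 4-(methylsulfanyl)phenyl, so it is only indirect guidance, and nothing recorded points to a large move in either direction. The expectation for compound 3 in this assay is therefore no step beyond the scatter, a 1.0-fold higher number from compound 1 to compound 3 (0.02 log units; within the scatter). Compound 3 is estimated at 500 nM, with a range from 200 nM to 1300 nM in this assay.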

Compound 3, half-maximal inhibitory concentration: 140 nM
Compound 3: middle estimate off by 3.6-fold (0.55 log units), on the high side, outside the stated range (below it).
By their numbers in this assay, from the lowest: compound 3; then compounds 2 and 1 (each within the scatter of the next).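

In this assay the aryl group on this aromatic carbon turns out to be a place where the number can move: replacing 3-fluorophenyl with 4-(methylsulfanyl)phenyl gives a 3.4-fold lower number from compound 1 to compound 3 (0.54 log units; beyond the scatter), while the earlier exchange on the same ring, a 1.0-fold lower number from compound 1 to compound 2 (0.02 log units; within the scatter), stayed inside the scatter. A flat response to the first substituent exchange therefore does not hold for every aryl group at this place, although only compound 3 goes beyond the scatter so far, and the step is modest. The step also changes two things at once, the substituent itself and its location on the ring, and no measurement shown gives a reason for the gain.

From the compounds shown here alone, what remains open is whether the gain follows the methylsulfanyl group or the location named in 4-(methylsulfanyl)phenyl, a question that 3-(methylsulfanyl)phenyl and 4-fluorophenyl at this place would address directly. Going by these compounds, it is also open how a methoxy group, a chlorine atom, an amine or a carboxylic acid in that location would read out, and whether a longer sulfur-bearing chain, such as ethylsulfanyl, would keep the lower number.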